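Moving an amino group onto a dichloropurine core

This account rests on a few compounds, and the source may have more. Where it says the series, first, only, none or still open, it means among the compounds named here.

Compound 1: `ClCc1ccccc1Cn1cnc2c(Cl)nc(Cl)nc21`, 1620 nM
Compound 2: `ClCc1cccc(Cn2cnc3c(Cl)nc(Cl)nc32)c1`, 5010 nM
Compound 3: `Nc1nc(Cl)c2ncn(Cc3ccccc3CCl)c2n1`, 67600 nM

Of the compounds shown here, three have been tested in a functional assay on PC-3 cells (Homo sapiens) for cytotoxicity, read by sulforhodamine B assay, with a stated time of 48 h; on this read-out lower numbers stand for stronger inhibition of growth and higher numbers for weaker inhibition of growth. Compound 1 `ClCc1ccccc1Cn1cnc2c(Cl)nc(Cl)nc21` gives 1620 nM in this assay. Compound 2 `ClCc1cccc(Cn2cnc3c(Cl)nc(Cl)nc32)c1` is built from the same atoms joined differently; how the two cores differ is not broken down here. In this assay compound 2 gives 5010 nM, so its number is higher than that of compound 1. Compound 3 `Nc1nc(Cl)c2ncn(Cc3ccccc3CCl)c2n1` differs from compound 1 in one place: amino in place of chloro on an aromatic carbon. That single change gives a 42-fold higher number from compound 1 to compound 3 (1.62 log units; beyond the scatter), a large step toward weaker inhibition of growth, with compound 3 giving 67600 nM in this assay.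

Compound 4 `Nc1nc(Cl)c2ncn(Cc3cccc(CCl)c3)c2n1` has not yet been measured. It relates to compound 2 as compound 3 relates to compound 1: amino in place of chloro on an aromatic carbon. The place description is the same word for word, so this is the same change made on the other core. Within the data shown here, only one measured example of this change exists, so the expectation rests on a single step. Among the measured compounds shown here, compound 4 is expected to show a 30-fold higher number from compound 2 to compound 4 (1.48 log units; beyond the scatter) in this assay, a step of about the same size as the one from compound 1 to compound 3, because a 42-fold higher number from compound 1 to compound 3 (1.62 log units; beyond the scatter) is the only guide available. Starting from the higher number of compound 2, compound 4 is therefore estimated at 150000 nM in this assay, with a plausible range from 40000 nM to 400000 nM.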

Compound 4, concentration for total growth inhibition: 25100 nM
Compound 4: the middle estimate sits 6.0-fold (0.78 log units) above what was measured; measured number outside the range, below it.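

Replacing chloro with amino on the core of compound 2 also moves the result toward weaker inhibition of growth in this assay, with a 5.0-fold higher number from compound 2 to compound 4 (0.70 log units; beyond the scatter), so the direction seen with the core of compound 1 is repeated on this second core. The size of the step, however, does not carry over from one core to the other: the same change on two cores in this assay, a 42-fold higher number (1.62 log units; beyond the scatter) from compound 1 to compound 3 and a 5.0-fold higher number (0.70 log units; beyond the scatter) from compound 2 to compound 4, 8.3-fold (0.92 log units) apart, beyond the scatter of two such steps

Within these four compounds, the change can therefore be trusted for its direction but not for its size, and with only two cores this shows no general rule, nor does it explain why the same swap costs more on one core than on the other.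

The compounds shown leave open how other groups would behave on the aromatic carbon between the two ring nitrogen atoms, such as a methylamino group, a dimethylamino group or a methoxy group, and whether any of them would fall closer to chloro or to amino. They also leave open whether the step would again differ in size on a third core, or in cells other than those used in this assay.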